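Moving the Hydroxyl on the Ring of Compound 1

This account rests on a few compounds, and the source may have more. Where it says the series, first, only, none or still open, it means among the compounds named here.

Compound 1 `CC1=C(/C=C/C(C)=C/C=C/C(C)=C\C(=O)Nc2ccc(O)cc2)C(C)(C)CCC1n1ccnc1` was tested in a functional assay on MDA-MB-468 cells (Homo sapiens) for inhibition, read by MTT assay (on this read-out higher numbers stand for weaker inhibition of growth and lower numbers for stronger inhibition of growth), where compound 1 gives 6830 nM. Among the measured compounds shown here, of the two numbers measured so far this is the highest, meaning the weakest growth inhibition; the other compound, compound 2 `CC1=C(/C=C/C(C)=C/C=C/C(C)=C\C(=O)NCc2ccc(O)cc2)C(C)(C)CCC1n1ccnc1`, gives 2700 nM. For the measured compounds named here, the only measured step, a 2.5-fold lower number from compound 1 to compound 2 (0.40 log units; beyond the scatter), comes from inserting a one-carbon link between the amide nitrogen and the ring, a change of a different kind from the one now considered. Compound 3 `CC1=C(/C=C/C(C)=C/C=C/C(C)=C\C(=O)Nc2ccccc2O)C(C)(C)CCC1n1ccnc1` differs from compound 1 by 2-hydroxyphenyl in place of 4-hydroxyphenyl on an amide-type nitrogen; the hydroxyl simply moves to another position on the same ring. Going by the values given here, no measured step bears on where the hydroxyl sits, so the expectation is no change beyond the scatter, and the step of a 1.1-fold lower number from compound 1 to compound 3 (0.06 log units; within the scatter) is therefore estimated as small, with a wide range of uncertainty. Compound 3 is accordingly expected to give about 6000 nM, estimated to lie between 2500 nM and 15000 nM.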

Compound 3, concentration for 50% growth inhibition: 3030 nM
Compound 3: the middle estimate sits 2.0-fold (0.30 log units) above what was measured; the measured number falls inside the stated range.
By their numbers in this assay, from the lowest: compounds 2 and 3 (each within the scatter of the next); then compound 1.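

In this assay, the place of the hydroxyl on the ring turns out to matter: with the same atoms joined differently, 2-hydroxyphenyl gives stronger growth inhibition than 4-hydroxyphenyl (a 2.3-fold lower number from compound 1 to compound 3 (0.35 log units; beyond the scatter)). The second step lies within the scatter (a 1.1-fold higher number from compound 2 to compound 3 (0.05 log units; within the scatter)), so 2-hydroxyphenyl and 4-hydroxybenzyl on the amide-type nitrogen cannot be told apart here, although each gives a lower number than compound 1. Nothing available explains why moving the hydroxyl changes the result.

Whether the hydroxyl is needed at all remains open, as the compounds shown do not include a plain phenyl group or a ring carrying a methoxy group or an amine instead. Also open, going by these compounds, is whether a 2-hydroxybenzyl group would combine the two changes to any benefit.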